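The source may hold more compounds than are shown below. What is called first, only, known or untested is meant among the compounds shown, and "the series" means these compounds.

Of the compounds shown here, three that share the same core have been measured in an assay on mitochondria from L6 cells (Rattus norvegicus) for activation, with a stated time of 90 min; on this read-out lower numbers stand for an effect already at smaller amounts and higher numbers for an effect only at larger amounts of compound. Compound 1 `Cc1cccc(Nc2nc3nonc3nc2Nc2cccc(C)c2)c1` gives 2100 nM in this assay. Compound 2 `Fc1cc(Br)ccc1Nc1nc2nonc2nc1Nc1ccc(Br)cc1F` gives no number in this assay but only a limit, < 3000 nM, which is the limit of < 3000 nM in this assay, at which 1 of the 3 values shown sits. Compound 3 `Fc1cccc(Nc2nc3nonc3nc2Nc2ccccc2F)c1` gives 190 nM in this assay, the lowest of the two numbers; compound 1 sits at a higher number, and that gap lies beyond the scatter.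

Compound 4 `CCOc1ccccc1Nc1nc2nonc2nc1Nc1ccccc1F` has not yet been measured in this assay. It differs from compound 3 in one place: 2-ethoxyphenyl in place of 3-fluorophenyl on a nitrogen on an aromatic ring. For the measured compounds named here, no pair of measured compounds shows what such a change does, so there is nothing to read the size of this step from directly. Exchanging 3-fluorophenyl for 2-ethoxyphenyl on the nitrogen is expected to shift the number by a moderate amount, most likely upward, although a step that stays within the scatter cannot be ruled out. The expected step is a 3.2-fold higher number from compound 3 to compound 4 (0.50 log units; beyond the scatter). For compound 4 the estimate in this assay is 600 nM, with a likely range from 120 nM to 3000 nM.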

Compound 4, half-maximal effective concentration: 5600 nM
Estimate against measurement, compound 4: 9.3-fold (0.97 log units) below, and the stated range ends below it.
By their numbers in this assay, from the lowest: compound 3; then compound 1; then compound 4.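

In this assay, for the compounds shown here, the exchange of 3-fluorophenyl for 2-ethoxyphenyl on the nitrogen gives the first measured step on the shared core that changes only one place, and that step is large: a 29-fold higher number from compound 3 to compound 4 (1.47 log units; beyond the scatter). This shows that the group on this nitrogen is not freely interchangeable, as this single change means that a much larger amount of compound is needed for the same effect. The entering group differs from the leaving one in several ways at once, with an ethoxy chain arriving, a fluorine leaving and a hydrogen-bond acceptor being added, and nothing shown here explains why the step is so large.

Which of these differences carries the step remains open, as one exchange changes them all together. Also open, going by these compounds, is how the number would respond to other groups on the phenyl ring at this nitrogen, such as a methoxy group, a longer alkoxy chain, an amine or a carboxylic acid, and whether any of them would keep the number close to that of compound 3.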